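Swapping tert-Butyl for 2-Cyanobenzyl: What to Expect

This account rests on a few compounds, and the source may have more. Where it says the series, first, only, none or still open, it means among the compounds named here.

Compound 1, `N#Cc1ccc(Cc2cnc(CCc3ccc(-c4ccccc4C(=O)O)cc3)[nH]2)cc1`, gives 5890 nM in an in vitro functional assay on cells for agonist activity at Bombesin receptor subtype-3 (Homo sapiens), read by luminescence and calcium flux; a higher number here means that more compound is needed for the effect, a lower number that less compound is needed.
Compound 2, `CC(C)(C)c1cnc(CCc2ccc(-c3ccccc3C(=O)O)cc2)[nH]1`, gives 4330 nM in this assay.

Among the measured compounds shown here, only two compounds have been measured so far, and they cannot be told apart: a 1.4-fold lower number from compound 1 to compound 2 (0.13 log units; within the scatter). For the measured compounds named here, compound 2 therefore stands at a number that is indistinguishable from that of compound 1, the only neighbour it has.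

The next compound, compound 3, `N#Cc1ccccc1Cc1cnc(CCc2ccc(-c3ccccc3C(=O)O)cc2)[nH]1`, differs from compound 2 in one place: 2-cyanobenzyl in place of tert-butyl on an aromatic carbon. Going by the values given here, the single measured step that bears on this is the one from compound 1 to compound 2, which exchanged a 4-cyanobenzyl for a tert-butyl and stayed within the scatter. Among the compounds with values here, the change to compound 3 runs the other way, putting a cyanobenzyl back, though now with the nitrile in the 2 position rather than the 4 position; no measured pair shows what that shift of the nitrile does.

Within the data shown here, with only that one flat step to go on, no movement beyond the scatter is expected, a 1.3-fold higher number from compound 2 to compound 3 (0.10 log units; within the scatter). Compound 3 is estimated at 5500 nM, with a likely range from 2000 nM to 15000 nM.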

Compound 3, half-maximal effective concentration: 5480 nM
The estimate for compound 3 lay 1.0-fold (0.00 log units) above the measured number; measured number inside the range.
By their numbers in this assay, from the lowest: compounds 2, 3 and 1 (each within the scatter of the next).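

The result shows that this aromatic carbon tolerates a much larger replacement in this assay without any readable shift: this assay gives a 1.3-fold higher number from compound 2 to compound 3 (0.10 log units; within the scatter), although the 2-cyanobenzyl brings 9 heavy atoms, a six-membered aromatic ring and a nitrile where the tert-butyl had 4 heavy atoms and no ring. Among the compounds shown here, the second new comparison answers what the earlier compounds could not, namely what happens when 2-cyanobenzyl stands in place of 4-cyanobenzyl: the step is a 1.1-fold lower number from compound 1 to compound 3 (0.03 log units; within the scatter), so these two cyanobenzyl groups cannot be told apart here. All three groups tried so far therefore give numbers within the scatter of one another, and none can be ranked above another.

Going by these compounds, whether any group on this carbon can move the number beyond the scatter remains open, for example an amine, a carboxylic acid, or a plain benzyl carrying no nitrile. No supporting measurement is available that would explain why these three compounds sit so close together.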